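The source may report more compounds than this note shows. Statements on the series, on what has been measured and on what is new or still open speak of the compounds shown alone.

Compound 1 `COc1ccc(CNc2nc([SeH])nc3ccccc23)cc1` gives 42700 nM in a functional assay on MCF7 cells (Homo sapiens) for cytotoxicity, read by MTT assay, with a stated time of 72 h; on this read-out lower numbers stand for stronger inhibition of growth and higher numbers for weaker inhibition of growth.
Compound 2 `Sc1nc(NCc2ccccc2)c2ccccc2n1` gives 27200 nM in this assay.

Compound 2 stands at the lower of these two numbers, but compound 1 lies within the usual scatter of it, so the two cannot be told apart. Compound 3 `COc1ccc(CNc2nc(S)nc3ccccc23)cc1`, not yet measured, differs from compound 2 by methoxy in place of hydrogen on an aromatic carbon. For the measured compounds named here, no measured pair shows what this change alone does, so no shift beyond the scatter is expected in this assay. The expected step of a 1.1-fold higher number from compound 2 to compound 3 (0.04 log units; within the scatter) is therefore small. Compound 3 is estimated at 30000 nM, within 12000 nM to 75000 nM.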

Compound 3, concentration for 50% growth inhibition: 7080 nM
Compound 3: middle estimate off by 4.2-fold (0.63 log units), on the high side; the measured number lies below the stated range.
By their numbers in this assay, from the lowest: compound 3; then compounds 2 and 1 (each within the scatter of the next).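

In this assay, methoxy in place of hydrogen, para to a large group, gives a 3.8-fold lower number from compound 2 to compound 3 (0.58 log units; beyond the scatter), so growth inhibition responds to a change at this place on the aromatic ring. With the methoxy kept, one sulfur atom in place of one selenium atom gives a 6.0-fold lower number from compound 1 to compound 3 (0.78 log units; beyond the scatter), so this atom on the core counts as well. Nothing measured here explains either step. Open questions remain: whether a chlorine atom, a hydroxyl or an amine at the same place would act like methoxy, and whether the sulfur-for-selenium step holds without the methoxy.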